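Swapping a thiadiazole for a phenyl-tetrazole on the sulfur

The source may report more compounds than this note shows. Statements on the series, on what has been measured and on what is new or still open speak of the compounds shown alone.

Three compounds share one core and differ in the group hanging from the sulfur and in the substituent on the outer phenyl ring. Compound 1, `O=C(CSc1nnnn1-c1ccccc1)N/N=c1/scc(-c2ccc(Br)cc2)n1-c1ccccc1`, was tested in a functional assay on C6 cells (Rattus norvegicus) for cytotoxicity, read by MTT assay, with a stated time of 24 h (on this read-out lower numbers stand for stronger inhibition and higher numbers for weaker inhibition), and gives 21 ug/mL. Compound 2, `Cc1nnc(SCC(=O)N/N=c2/scc(-c3ccc(C#N)cc3)n2-c2ccccc2)s1`, gives "not determined" (no result reported) in this assay, so nothing can be said about where it stands. Compound 3, `N#Cc1ccc(-c2cs/c(=N/NC(=O)CSc3nnnn3-c3ccccc3)n2-c2ccccc2)cc1`, differs from compound 2 by 1-phenyl-1H-tetrazol-5-yl in place of 5-methyl-1,3,4-thiadiazol-2-yl on a sulfur. Since compound 2 has no number, the step from compound 2 to compound 3 cannot be sized from measured values. For the measured compounds named here, the group that enters in compound 3 is the one already present in compound 1, and the remaining difference between compound 1 and compound 3 is the substituent on the outer ring. Compound 3 is therefore expected to land near compound 1, because compound 1 gives 21 ug/mL, with an estimate of 22 ug/mL and a range from 8 ug/mL to 60 ug/mL.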

Compound 3, half-maximal inhibitory concentration: > 200 ug/mL
Compound 3: a limit, no number; the forecaster's own chance of this, stated with the estimate: 10%; middle value at least 9.0-fold (0.95 log units) from the limit.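

With the 1-phenyl-1H-tetrazol-5-yl group held fixed on the sulfur, cyano in place of bromo on an aromatic carbon gives an at least 9.5-fold higher number from compound 1 to compound 3 (0.97 log units; beyond the scatter) in this assay, meaning much weaker inhibition. For the compounds shown here, this is the first measured sign that, in this pair, the substituent on the outer ring strongly changes the read-out, and that the group on the sulfur does not fix the result by itself. From the compounds shown here alone, the result for compound 3 is a limit and not a number, so the true size of the step stays unknown: the limit of > 200 ug/mL in this assay, at which 1 of the 3 values shown sits.

The step from compound 2 to compound 3 cannot be read, so the effect of the swap on the sulfur remains unsized. The compounds shown also leave open how a chloro, methoxy or amine group on that aromatic carbon would compare with bromo and cyano.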